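Changing a Benzyl Halogen in a Cytotoxicity Series

This account rests on a few compounds, and the source may have more. Where it says the series, first, only, none or still open, it means among the compounds named here.

Compounds measured so far:
compound 1, `C=CC1=C(C(=O)NC(C)(C)C)C(c2ccc(OC)cc2)OC1`: > 100000 nM
compound 2, `C=CC1=C(C(=O)NCc2ccccc2F)C(c2ccc(F)cc2)OC1`: > 100000 nM
compound 3, `C=CC1=C(C(=O)Nc2ccccc2)C(c2ccc(OC)c(OC)c2)OC1`: > 100000 nM

All three share one core and differ only in the groups attached to it. In a functional assay on A549 cells (Homo sapiens) for cytotoxicity, read by MTT assay, with a stated time of 24 h (on this read-out lower numbers stand for stronger inhibition and higher numbers for weaker inhibition), compound 1 gives > 100000 nM, which is a limit of the assay rather than a number. Compound 2 likewise gives > 100000 nM in this assay, again a limit. Compound 3 gives > 100000 nM in this assay, also a limit. Compound 2 therefore stands where every value stands, because of the limit of > 100000 nM in this assay, at which 3 of the 3 values shown sit.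

Compound 4, `C=CC1=C(C(=O)NCc2ccc(Cl)cc2)C(c2ccc(F)cc2)OC1`, is not yet measured. It differs from compound 2 in one place: 4-chlorophenyl in place of 2-fluorophenyl on a saturated chain carbon bound to an amide-type nitrogen.

Among the compounds with values here, no step between two measured compounds is available to guide the expectation, so no shift beyond the usual scatter is expected, and the estimated step of a number no higher from compound 2 to compound 4 (the limit leaves the size open) is set accordingly. Compound 4 is expected to give about 100000 nM in this assay, within 50000 nM to 300000 nM, most likely again as a limit.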

Compound 4, half-maximal inhibitory concentration: > 100000 nM
Compound 4: a limit, no number; the forecaster's own chance of this, stated with the estimate: 85%; the middle value lies on the limit itself.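

No step can be read from compound 2 to compound 4, because both values are limits of the assay and not numbers: the limit of > 100000 nM in this assay, at which 4 of the 4 values shown sit. The compounds shown leave open how strongly any of them acts, and whether 4-chlorophenyl in place of 2-fluorophenyl changes anything.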